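Nitrofuran Amides in a HeLa Cytotoxicity Screen

The compounds below may be only part of what the source reports. "The series", "measured", "known", "first", "only" and "open" are said of these compounds alone.

Compound 1 `O=C(Nc1cccc(C(F)(F)F)c1)c1ccc([N+](=O)[O-])o1` and compound 2 `O=C(Nc1cc(C(F)(F)F)cc(C(F)(F)F)c1)c1ccc([N+](=O)[O-])o1` share one core, while compound 3 `O=C(Nc1ccc(O)cc1)c1ccc([N+](=O)[O-])o1` carries another; how the core of compound 3 differs from that of compound 1 is not broken down here. In an ADME assay on HeLa cells (Homo sapiens) for cytotoxicity, read by resazurin assay, with a stated time of 65 h (a lower number here means that less compound is needed, a higher number that more compound is needed for the effect), compound 1 gives only a limit, > 20000 nM. Compound 2 likewise gives only a limit in this assay, > 10000 nM. The change between them, (trifluoromethyl in place of hydrogen on an aromatic carbon), therefore yields a step that the two limits leave unreadable from compound 1 to compound 2; the two limits behind this are the limit of > 10000 nM in this assay, at which 1 of the 3 values shown sits, and (the limit of > 20000 nM in this assay, at which 2 of the 3 values shown sit). Compound 3 also returns a limit in this assay, > 20000 nM.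

Compound 4 `O=C(Nc1ccc(O)c(C(F)(F)F)c1)c1ccc([N+](=O)[O-])o1` has not yet been measured. It arises from compound 3 through (trifluoromethyl in place of hydrogen on an aromatic carbon), the same kind of change as that from compound 1 to compound 2, though here the entering group sits ortho to a hydroxy group and meta to a large group, rather than meta to a large group and meta to a trifluoromethyl group. The expectation for compound 4 rests on compound 3, which gives only a limit, > 20000 nM. Compound 4 is expected to sit near 30000 nM, between 12000 nM and 100000 nM. That expectation means an estimated step that the limit leaves unreadable from compound 3 to compound 4.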

Compound 4, half-maximal effective concentration: > 20000 nM
Compound 4: no number, only a limit; the forecaster's own chance of this, stated with the estimate: 85%; the middle value does not contradict the limit.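

Compound 4 returns only a limit in this assay, as do compound 1 and compound 3, so neither the step from compound 3 to compound 4 nor that from compound 1 to compound 4 can be read. The compounds shown leave open whether trifluoromethyl or hydroxy in place of hydrogen on an aromatic carbon changes the half-maximal effective concentration at all.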